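The source may hold more compounds than are shown below. What is called first, only, known or untested is meant among the compounds shown, and "the series" means these compounds.

Working notes on the series. Compound 2, `CC[C@@H](Nc1c(C#N)c(-c2ccc(-c3ccccc3OC)cc2)nc2cnccc12)C(N)=O`, is the reference point for the next step. In a physicochemical assay for lipophilicity, read by HPLC, at pH 7.5 (a higher number here means a more lipophilic compound, a lower number a more polar compound), compound 2 gives 2.7. Compound 1, `CC[C@@H](Nc1c(C#N)c(-c2ccc(-c3cccc(OC)c3)cc2)nc2cnccc12)C(N)=O`, gives 2.7 in this assay, so compound 2 stands level with compound 1 at the digits shown, the two together the highest of the three numbers; the step of no change at the digits printed from compound 1 to compound 2 (within the scatter) moved nothing beyond the scatter. Within the data shown here, compound 3, `CC[C@@H](Nc1c(C#N)c(-c2ccc(-c3cccc(C)c3F)cc2)nc2cnccc12)C(=O)O`, gives 2.1, a number well beneath both, but it carries the carboxylic acid in place of the amide as well as a different aryl group, so no single-change step connects it to compound 2.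

Compound 4 is `CC[C@@H](Nc1c(C#N)c(-c2ccc(-c3cccc(CO)c3)cc2)nc2cnccc12)C(N)=O`. The change from compound 2 is 3-(hydroxymethyl)phenyl in place of 2-methoxyphenyl on an aromatic carbon. Among the measured compounds shown here, the one measured step, from compound 1 to compound 2, only moved a methoxy around the ring and left the number unchanged; it does not address a new hydrogen-bond donor entering. The expectation is a clear drop in this assay, with the step of a number 0.90 log units lower from compound 2 to compound 4 (beyond the scatter) expected. Compound 4 is therefore estimated at 1.8, with a range from 1.4 to 2.2.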

Compound 4, distribution coefficient: 2
Estimate against measurement, compound 4: 0.20 log units below; the range from low to high includes it.
By their numbers in this assay, from the lowest: compounds 4 and 3 (each within the scatter of the next); then compounds 1 and 2 (each within the scatter of the next).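

In this assay, this position proves responsive to the group it carries: hydroxymethyl in place of methoxy on an aromatic carbon gives a number 0.70 log units lower from compound 1 to compound 4 (beyond the scatter), and 3-(hydroxymethyl)phenyl in place of 2-methoxyphenyl gives a number 0.70 log units lower from compound 2 to compound 4 (beyond the scatter). The earlier step between the two methoxy compounds, no change at the digits printed from compound 1 to compound 2 (within the scatter), showed only that moving the methoxy left the number in place, whereas this change, with the same heavy-atom count, brings in a hydrogen-bond donor and moves the number beyond the scatter. No measurement is available that explains this shift.

On these data alone, how an aminomethyl group or a longer chain such as hydroxyethyl would read at this position stays open. A methyl ether of the hydroxymethyl group, a methoxymethyl group, would also help to show whether the donor itself goes with the shift.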